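Moving the Trifluoromethyl Group Around the Pendant Ring

The compounds below may be only part of what the source reports. "The series", "measured", "known", "first", "only" and "open" are said of these compounds alone.

Compound 1 `Oc1ccc(-c2cc(-c3ccccc3F)cc(-c3ccccc3O)n2)cc1` reaches in a functional assay on HCT-15 cells (Homo sapiens) for inhibition (on this read-out lower numbers stand for stronger inhibition and higher numbers for weaker inhibition), only the assay limit > 50000 nM.
Compound 2 `Oc1ccccc1-c1cc(-c2ccc(C(F)(F)F)cc2)cc(-c2ccccc2O)n1` likewise reaches only the assay limit > 50000 nM.
Compound 3 `Oc1ccc(-c2cc(-c3ccccc3C(F)(F)F)cc(-c3ccccc3O)n2)cc1` gives in this assay 8990 nM.

Among the compounds with values here, compound 3 is thus the only compound with a measured number; the other two sit at the limit of > 50000 nM in this assay, at which 2 of the 3 values shown sit. The step of an at least 5.5-fold lower number from compound 1 to compound 3 (0.74 log units; beyond the scatter) shows that a trifluoromethyl group at the ortho position helps. Compound 4 `Oc1ccc(-c2cc(-c3ccc(C(F)(F)F)cc3)cc(-c3ccccc3O)n2)cc1` differs from compound 3 by 4-(trifluoromethyl)phenyl in place of 2-(trifluoromethyl)phenyl on an aromatic carbon. Within the data shown here, no measured step covers this move, and compound 2, which also carries a 4-(trifluoromethyl)phenyl group, sits at the limit. The expected step is therefore a modest loss, a 2.8-fold higher number from compound 3 to compound 4 (0.44 log units; beyond the scatter). Compound 4 is estimated at 25000 nM, in the range 6000 nM to 80000 nM.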

Compound 4, half-maximal inhibitory concentration: > 50000 nM
Compound 4 gave a limit, no number; the forecaster's own chance of this, stated with the estimate: 40%; middle value at least 2.0-fold (0.30 log units) away from the limit.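

Compound 3 and compound 4 have the same atoms, joined differently, yet swapping 2-(trifluoromethyl)phenyl for 4-(trifluoromethyl)phenyl in this assay gives an at least 5.5-fold higher number from compound 3 to compound 4 (0.74 log units; beyond the scatter). Among these compounds, then, the measurable inhibition of compound 3 depends on where the trifluoromethyl group sits on the pendant ring, not merely on its presence. The steps from compound 1 and from compound 2 to compound 4 cannot be read: the limit of > 50000 nM in this assay, at which 3 of the 4 values shown sit.

Still open, going by these compounds, is whether an amine or a carboxylic acid in place of the trifluoromethyl group of compound 3 would keep any inhibition.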